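Side-chain steps ahead of compound 4

The compounds below may be only part of what the source reports. "The series", "measured", "known", "first", "only" and "open" are said of these compounds alone.

- Compound 1 `O=C1c2c[n+]([O-])c3ccccc3c2C(=O)c2c1c1ccccc1n2CCCCN1CCCCC1` gives 230 nM in a functional assay on SH-SY5Y cells (Homo sapiens) for cytotoxicity, read by MTT assay, with a stated time of 72 h; on this read-out lower numbers stand for stronger inhibition and higher numbers for weaker inhibition
- Compound 2 `CCCN1CCN(CCCCn2c3c(c4ccccc42)C(=O)c2c[n+]([O-])c4ccccc4c2C3=O)CC1` gives 3970 nM in this assay
- Compound 3 `O=C1c2c[n+]([O-])c3ccccc3c2C(=O)c2c1c1ccccc1n2CCN1CCCCC1` gives 1860 nM in this assay

Compound 3 at 1860 nM holds the second highest of the three numbers. Its nearest step is a 2.1-fold lower number from compound 2 to compound 3 (0.33 log units; beyond the scatter) and its furthest is an 8.1-fold higher number from compound 1 to compound 3 (0.91 log units; beyond the scatter) on the same read-out.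

Compound 4 `O=C1c2c[n+]([O-])c3ccccc3c2C(=O)c2c1c1ccccc1n2CCCN1CCC(O)CC1` is still unmeasured. The change is (4-hydroxypiperidin-1-yl)methyl in place of piperidin-1-yl on a saturated chain carbon, two bonds along the chain from an aromatic nitrogen and reads as (4-hydroxypiperidin-1-yl)methyl in place of piperidin-1-yl on a saturated chain carbon, two bonds along the chain from an aromatic nitrogen. The chain of compound 4 is longer than that of compound 3 and shorter than that of compound 1.

Two further points temper the comparison. The chain step an 8.1-fold higher number from compound 1 to compound 3 (0.91 log units; beyond the scatter) points to a lower number with a longer chain, yet compound 2 goes against this, as the ring-end step a 17-fold higher number from compound 1 to compound 2 (1.24 log units; beyond the scatter) shows a large rise. For the measured compounds named here, no measured compound carries the 4-hydroxypiperidin-1-yl group, so that part of the change is untested.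

In this assay the estimated change is a 2.1-fold lower number from compound 3 to compound 4 (0.32 log units; beyond the scatter) and a modest drop is expected. The expected value for compound 4 is 900 nM (estimated range 250 nM to 3200 nM).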

Compound 4, half-maximal inhibitory concentration: 130 nM
Beside the measured number, compound 4's estimate is 6.9-fold (0.84 log units) above it, outside the stated range (below it).
By their numbers in this assay, from the lowest: compounds 4 and 1 (each within the scatter of the next); then compound 3; then compound 2.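

In this assay the 3-(4-hydroxypiperidin-1-yl)propyl chain puts compound 4 at the low end of the series, with a large step from the 2-(piperidin-1-yl)ethyl chain (a 14-fold lower number from compound 3 to compound 4 (1.16 log units; beyond the scatter)) and a larger one from the chain ending in 4-propylpiperazin-1-yl (a 31-fold lower number from compound 2 to compound 4 (1.48 log units; beyond the scatter)). A longer chain ending in piperidin-1-yl is therefore not the only route to the low end, since compound 4 cannot be told apart from compound 1 (a 1.8-fold lower number from compound 1 to compound 4 (0.25 log units; within the scatter)), a step within the scatter. No data on hand explain these steps, so they stand as observations only.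

On these data alone, the change from compound 3 joins a longer chain to a hydroxy group on the ring, so the share of each remains open; the 3-(piperidin-1-yl)propyl and 2-(4-hydroxypiperidin-1-yl)ethyl chains would separate the two. Also open, as far as these compounds go, is how a methoxy group or a primary amine in place of the hydroxy group would read, and whether a longer chain ending in 4-hydroxypiperidin-1-yl would keep the number of compound 4.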